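Methoxy added to compound 2: expected effect

The compounds below may be only part of what the source reports. "The series", "measured", "known", "first", "only" and "open" are said of these compounds alone.

In a functional assay on CNE-2 cells (Homo sapiens) for antiproliferative activity, read by sulforhodamine B assay, with a stated time of 48 h (a lower number here means a stronger inhibitor, a higher number a weaker inhibitor), compound 2 (`O=C(/C=C/c1ccccc1-c1ccc(F)cc1)c1cccc(O)c1`) gives 7300 nM and lies within the scatter of compound 1 (`COc1ccc(C(=O)/C=C/c2ccccc2-c2ccc(F)cc2)cc1` at 9000 nM). Compound 3 (`COc1ccc(C(=O)/C=C/c2ccccc2-c2ccc(F)cc2)cc1O`) takes methoxy in place of hydrogen on an aromatic carbon, ortho to a hydroxy group and para to a large group (methoxy in place of hydrogen on an aromatic carbon). For the measured compounds named here, the one measured step (a 1.2-fold lower number from compound 1 to compound 2 (0.09 log units; within the scatter)) stays within the scatter, so no step beyond the scatter is expected from the added methoxy in this assay and no direction is favoured. The estimated step is small (a 1.3-fold lower number from compound 2 to compound 3 (0.12 log units; within the scatter)). Compound 3 is expected at 5500 nM (estimated range 1500 nM to 15000 nM).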

Compound 3, half-maximal inhibitory concentration: 750 nM
Beside the measured number, compound 3's estimate is 7.3-fold (0.87 log units) above it; the whole stated range lies above it.
By their numbers in this assay, from the lowest: compound 3; then compounds 2 and 1 (each within the scatter of the next).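

In this assay, methoxy in place of hydrogen, ortho to a hydroxy group and para to a large group, gives (a 9.7-fold lower number from compound 2 to compound 3 (0.99 log units; beyond the scatter)). Adding a hydroxy group to the ring gives (a 12-fold lower number from compound 1 to compound 3 (1.08 log units; beyond the scatter)), so the large gain appears only with both groups on the ring, which compound 1 and compound 2, each carrying one, could not show. Nothing available bears on the reason for this result.

As far as these compounds go, whether an ethoxy group in place of the methoxy, or an amine in place of the hydroxy, would keep this gain stays open.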